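The source may hold more compounds than are shown below. What is called first, only, known or untested is meant among the compounds shown, and "the series" means these compounds.

Compound 1 `N=C(N)c1ccc(-c2ccc(-c3ccccc3)s2)s1` gives 15.3% in an ADME assay on cells (Erythrocyte, Homo sapiens) for activation, read by hemolysis, with a stated time of 30 min, tested at 2.5 mM (on this read-out higher numbers stand for a stronger effect at the one concentration tested and lower numbers for a weaker effect), the top of the two numbers measured, yet only within the scatter of compound 2 `N=C(N)c1ccc(-c2ccc(-c3ccc(F)cc3)s2)s1`, which gives 14%. Within the data shown here, the one measured step, a number 1.3 percentage points lower from compound 1 to compound 2 (within the scatter), is the only one that bears on the question, and it is small. Compound 3 `COc1cccc(-c2ccc(-c3ccc(C(=N)N)s3)s2)c1` differs from compound 1 in one place: methoxy in place of hydrogen on an aromatic carbon. No measured step matches this change, and the single step shown is within the scatter, so no step beyond the scatter is expected in this assay. Compound 3 is therefore expected to give 15% (range 5% to 28%), an expected step of a number 0.3 percentage points lower from compound 1 to compound 3 (within the scatter).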

Compound 3, a percentage reported as activity, at one concentration (the size of the read-out at that concentration, not a potency): 16.1%
For compound 3 the middle estimate is 1.1 percentage points below the measured one; the measured number falls inside the stated range.
By their numbers in this assay, from the lowest: compounds 2, 1 and 3 (each within the scatter of the next).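

In this assay, the step for methoxy in place of hydrogen on an aromatic carbon, meta to a large group, is a number 0.8 percentage points higher from compound 1 to compound 3 (within the scatter). This change adds 2 heavy atoms and 1 hydrogen-bond acceptor to the six-membered aromatic ring, yet the step still stays within the scatter, as does a number 1.3 percentage points lower from compound 1 to compound 2 (within the scatter) for the fluoro change. No measurement at hand bears on the reason for this result. From the compounds shown here alone, whether an amine or a carboxylic acid at this position would give a step beyond the scatter remains open. So does the effect of methoxy elsewhere on this ring.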